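Shrinking the ring on the shared core

The source may hold more compounds than are shown below. What is called first, only, known or untested is meant among the compounds shown, and "the series" means these compounds.

Compound 1 `CCCCCCCCOP(=O)(O)OCCSC(=S)N1CCCCCC1` is the starting point. In an ADME assay on HEK293 cells (Homo sapiens) for inhibition, read by MTT assay, with stated times of 18 h and 4 h (on this read-out lower numbers stand for stronger inhibition and higher numbers for weaker inhibition), compound 1 gives > 100000 nM, which is a limit of the assay rather than a measured number (the limit of > 100000 nM in this assay, at which 1 of the 3 values shown sits). Two relatives with shorter chains have been measured: compound 2 `CCCOP(=O)(O)OCCSC(=S)N1CCCCCC1` gives 54000 nM in this assay, and compound 3 `CCCCCCOP(=O)(O)OCCSC(=S)N1CCCCCC1` gives 70500 nM. The steps among them, an at least 1.8-fold lower number from compound 1 to compound 2 (0.26 log units; that floor lies within the scatter), an at least 1.4-fold lower number from compound 1 to compound 3 (0.15 log units; that floor lies within the scatter) and a 1.3-fold higher number from compound 2 to compound 3 (0.12 log units; within the scatter), all concern the chain and stay within the scatter. Compound 4 `CCCCCCCCOP(=O)(O)OCCSC(=S)N1CCCCC1` differs from compound 1 in piperidin-1-yl in place of azepan-1-yl on a thiocarbonyl carbon. Among the measured compounds shown here, no measured step touches this ring, so no shift beyond the scatter is expected in this assay, and compound 4 is estimated at 100000 nM, within 45000 nM to 250000 nM. The expected step is a number no higher from compound 1 to compound 4 (the limit leaves the size open), with a fair chance that only a limit is again reported.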

Compound 4, half-maximal inhibitory concentration: 69000 nM
Compound 4: middle estimate off by 1.4-fold (0.16 log units), on the high side, within the range that was stated.
By their numbers in this assay, from the lowest: compounds 2, 4 and 3 (each within the scatter of the next). At a limit, above all of these: compound 1.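

Replacing azepan-1-yl with piperidin-1-yl on the thiocarbonyl carbon gives an at least 1.4-fold lower number from compound 1 to compound 4 (0.16 log units; that floor lies within the scatter) in this assay, so this ring position now has its first reading, and a small ring change leaves no shift beyond the scatter. The true size of the step cannot be read because compound 1 sits at a limit, not at a number: the limit of > 100000 nM in this assay, at which 1 of the 4 values shown sits.

On these data alone, whether morpholin-4-yl or pyrrolidin-1-yl on the thiocarbonyl carbon would move the number beyond the scatter remains open. So does whether this ring change would behave the same with a propyl chain, as in compound 2.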